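The compounds below may be only part of what the source reports. "The series", "measured", "known", "first", "only" and "open" are said of these compounds alone.

Working notes on the series. Compound 1 `COc1ccc(C(=O)/C=C/c2ccc([N+](=O)[O-])cc2)c2c1C=CC(C)(C)O2` gives 3730 nM in a functional assay on HT-29 cells (Homo sapiens) for antiproliferative activity, read by MTT assay, with a stated time of 24 h; a lower number here means a stronger inhibitor, a higher number a weaker inhibitor. Among the measured compounds shown here, compound 2 `COc1ccc(C(=O)/C=C/c2ccc(Cl)c(Cl)c2)c2c1C=CC(C)(C)O2` gives 7580 nM in this assay, which puts it at the higher end of the two numbers so far; the swap recorded as a 2.0-fold higher number from compound 1 to compound 2 (0.31 log units; beyond the scatter) is the only step measured, a modest rise beyond the scatter.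

Compound 3 `COc1ccccc1/C=C/C(=O)c1ccc(OC)c2c1OC(C)(C)C=C2` differs from compound 2 by 2-methoxyphenyl in place of 3,4-dichlorophenyl on a double-bonded chain carbon bound to a double-bonded chain carbon. For the measured compounds named here, the single step in hand, from compound 1 to compound 2, also exchanges the aryl group on the chain carbon, so it is the only guide, and it was a modest move of a 2.0-fold higher number from compound 1 to compound 2 (0.31 log units; beyond the scatter). Going by the values given here, no step involving a methoxyphenyl group has been measured. The change from compound 2 to compound 3 is therefore expected to be small, most likely within or just beyond the scatter, with the direction uncertain. The estimate for compound 3 is 9000 nM, within 3000 nM to 27000 nM, corresponding to an expected step of a 1.2-fold higher number from compound 2 to compound 3 (0.07 log units; within the scatter).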

Compound 3, half-maximal inhibitory concentration: > 10000 nM
Compound 3 gave a limit, no number (the forecaster's own chance of this, stated with the estimate: 15%); at least 1.1-fold (0.04 log units) between middle value and limit.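

Compound 3 gives only a limit in this assay, not a number: the limit of > 10000 nM in this assay, at which 1 of the 3 values shown sits. With 2-methoxyphenyl on this chain carbon the series shows an at least 2.6-fold higher number from compound 1 to compound 3 (0.42 log units; beyond the scatter), so exchanging the 4-nitrophenyl group for this group raises the number beyond the scatter, and by more than the earlier aryl exchange need imply, although only a floor is known. Against 3,4-dichlorophenyl the result is an at least 1.3-fold higher number from compound 2 to compound 3 (0.12 log units; that floor lies within the scatter), a floor that does not separate compound 3 from compound 2.

How far the true value of compound 3 lies past its limit cannot be read from these data. Also open, on these data alone, is whether an aryl group carrying an amine or a carboxylic acid on this chain carbon would give a lower number than compound 1.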